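The source may hold more compounds than are shown below. What is called first, only, known or untested is meant among the compounds shown, and "the series" means these compounds.

Measured compounds:
compound 1, `COc1ccc(OC(=O)Nc2ccc([Se]C#N)cc2)cc1`, 19200 nM
compound 2, `CCCCOC(=O)Nc1ccc([Se]C#N)cc1`, 14500 nM
compound 3, `CCCCCCOC(=O)Nc1ccc([Se][Se]c2ccc(NC(=O)OCCCCCC)cc2)cc1`, 9800 nM

In an ADME assay on 184B5 cells (Homo sapiens) for cytotoxicity, read by MTT assay, with a stated time of 72 h (on this read-out lower numbers stand for stronger inhibition of growth and higher numbers for weaker inhibition of growth), the three measured compounds sit close together. Compound 2 stands between the others, and its value differs from compound 1 and from compound 3 by amounts that fall within the usual scatter of repeated measurements, so no order among them can be claimed.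

Compound 4, `CCOC(=O)Nc1ccc([Se]C#N)cc1`, has not yet been measured. It differs from compound 2 by hydrogen in place of ethyl on a saturated chain carbon, two bonds along the chain from an oxygen next to a carbonyl group. Among the compounds with values here, no step between measured compounds shortens a chain in this way, so nothing measured speaks for a change beyond the scatter. The step from compound 2 to compound 4 is expected to be small, a 1.2-fold higher number from compound 2 to compound 4 (0.07 log units; within the scatter), in this assay. Compound 4 is therefore estimated at 17000 nM, with a range from 8000 nM to 36000 nM.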

Compound 4, concentration for total growth inhibition: 18600 nM
Compound 4: the middle estimate sits 1.1-fold (0.04 log units) below what was measured; the measured number falls inside the stated range.
By their numbers in this assay, from the lowest: compounds 3, 2, 4 and 1 (each within the scatter of the next).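

In this assay, butyl giving way to ethyl produces a 1.3-fold higher number from compound 2 to compound 4 (0.11 log units; within the scatter). This is the only step shown at this position, and it gives a first direct reading: removing ethyl from this saturated chain carbon brings no change that can be told from the scatter. No available evidence bears on this result. The compounds shown leave open whether an amine or a carboxylic acid at the end of this chain would move the number beyond the scatter. On these data alone, a much longer chain remains equally open.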